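Extending the side chain from carboxy to hydroxypropyl

The source may report more compounds than this note shows. Statements on the series, on what has been measured and on what is new or still open speak of the compounds shown alone.

The study turns on a spiro-fused core carrying an amide-linked side chain, tested in an assay on HEK293 cells for displacement of a labelled ligand from NPC1-like intracellular cholesterol transporter 1 (Homo sapiens); a lower number here means a stronger inhibitor, a higher number a weaker inhibitor. Compound 1 `CC(C)(C)c1ccc(C(=O)N2CCC3(CC2)C(=O)N(CC(=O)NCCC(=O)O)CN3c2ccccc2)cc1` gives 11400 nM in this assay, the highest number of the three measured compounds. Compound 2 `CC(C)(C)OC(=O)NCCCCNC(=O)CN1CN(c2ccccc2)C2(CCN(C(=O)c3ccc(C4CCCCC4)cc3)CC2)C1=O` gives 4600 nM, and compound 3 `CS(=O)(=O)NCCNC(=O)CN1CN(c2ccccc2)C2(CCN(C(=O)c3ccc(C4CCCCC4)cc3)CC2)C1=O` gives 2100 nM; compound 2 and compound 3 differ from compound 1 at more than one place, so their gaps to compound 1 cannot be traced to a single change.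

Compound 4 `CC(C)(C)c1ccc(C(=O)N2CCC3(CC2)C(=O)N(CC(=O)NCCCCCO)CN3c2ccccc2)cc1` is not yet measured and differs from compound 1 in one place: 3-hydroxypropyl in place of carboxy on a saturated chain carbon, two bonds along the chain from an amide-type nitrogen. Within the data shown here, the only measured step of a comparable kind alters the terminal group on the same side chain, and it moved a 2.2-fold lower number from compound 2 to compound 3 (0.34 log units; beyond the scatter). That step is modest, and the change from compound 1 to compound 4 again exchanges one polar end group for another at the same place, so a modest movement in the same direction is expected in this assay, though with wide uncertainty. Compound 4 is therefore estimated at 6500 nM, within 2500 nM to 16000 nM, which means an expected step of a 1.8-fold lower number from compound 1 to compound 4 (0.24 log units; within the scatter).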

Compound 4, half-maximal inhibitory concentration: 9400 nM
The estimate for compound 4 lay 1.4-fold (0.16 log units) below the measured number; measured number inside the range.
By their numbers in this assay, from the lowest: compound 3; then compound 2; then compounds 4 and 1 (each within the scatter of the next).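

In this assay, 3-hydroxypropyl in place of carboxy on a saturated chain carbon, two bonds along the chain from an amide-type nitrogen, gives a 1.2-fold lower number from compound 1 to compound 4 (0.08 log units; within the scatter), so this exchange does not separate the two compounds. Among these compounds, this is the first comparison on the core of compound 1 that differs in one place only, and it shows that the carboxy end of the side chain can be exchanged for 3-hydroxypropyl without a step beyond the scatter. Nothing available explains why the two end groups read alike.

From the compounds shown here alone, whether an amine, a primary amide or a longer chain ending in hydroxy would read differently at this place remains open. Also open, going by these compounds, is whether the same exchange would give a similar result on the core of compound 3.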